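Methoxy for Tert-Butyl: Expected Cytotoxicity in Fibroblasts

This account rests on a few compounds, and the source may have more. Where it says the series, first, only, none or still open, it means among the compounds named here.

Compound 1, `Cc1cc(NC(=O)Nc2ccccc2F)c2ccccc2n1`: in an ADME assay on BJ cells (Homo sapiens) for cytotoxicity, with a stated time of 72 h (a higher number here means that more compound is needed for the effect, a lower number that less compound is needed), compound 1 reaches only the assay limit, > 25000 nM.
Compound 2, `Cc1cc(NC(=O)Nc2ccccc2[N+](=O)[O-])c2ccccc2n1`: in this assay compound 2 also reaches only the assay limit, > 25000 nM.
Compound 3, `Cc1cc(NC(=O)Nc2ccccc2C(C)(C)C)c2ccccc2n1`: in this assay compound 3 gives 22000 nM.

Compound 3 is thus the only one of the three with a real number; the other two sit at the limit of > 25000 nM in this assay, at which 2 of the 3 values shown sit. As far as these compounds go, the two measured steps that arrive at compound 3 are an at least 1.1-fold lower number from compound 1 to compound 3 (0.05 log units; that floor lies within the scatter) and an at least 1.1-fold lower number from compound 2 to compound 3 (0.05 log units; that floor lies within the scatter); each changes the group on the same aromatic carbon, and each has a floor that lies within the scatter, so their true size is unknown. The remaining step, a step that the two limits leave unreadable from compound 1 to compound 2, shows no size at all.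

Compound 4, `COc1ccccc1NC(=O)Nc1cc(C)nc2ccccc12`, differs from compound 3 by methoxy in place of tert-butyl on an aromatic carbon. Because the steps of an at least 1.1-fold lower number from compound 1 to compound 3 (0.05 log units; that floor lies within the scatter) and an at least 1.1-fold lower number from compound 2 to compound 3 (0.05 log units; that floor lies within the scatter) show that two other groups on that carbon led only to limits, the step of a 1.2-fold higher number from compound 3 to compound 4 (0.07 log units; within the scatter) is expected to be small, at most within the scatter and if anything toward a higher number. Compound 4 is therefore estimated at 26000 nM in this assay, between 12000 nM and 60000 nM, with a real chance that only a limit is reported.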

Compound 4, half-maximal effective concentration in the BJ assay: > 25000 nM
Compound 4 ended at the assay's limit; the forecaster's own chance of this, stated with the estimate: 60%; the middle value does not contradict the limit.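

Replacing tert-butyl with methoxy gives, in the BJ assay, an at least 1.1-fold higher number from compound 3 to compound 4 (0.05 log units; that floor lies within the scatter), so this change shows no effect of readable size; the steps from compound 1 and from compound 2 to compound 4 cannot be read. Tert-butyl therefore remains the only group on this aromatic carbon with a real number in this assay, while compound 1, compound 2 and compound 4 all end at the same place: the limit of > 25000 nM in the BJ assay, at which 3 of the 4 values shown sit. In a physicochemical assay for solubility, at pH 7.4 (on this read-out higher numbers stand for higher solubility and lower numbers for lower solubility), compound 3 gives 100 nM and compound 4 gives 100 nM, which is no change at the digits printed from compound 3 to compound 4 (within the scatter).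

As far as these compounds go, how far the true values of compound 1, compound 2 and compound 4 lie beyond that limit stays open, so these three cannot be ranked. Also open, from the compounds shown here alone, is what an amine or a carboxylic acid on this carbon would do in the BJ assay.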